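The source may report more compounds than this note shows. Statements on the series, on what has been measured and on what is new or still open speak of the compounds shown alone.

The compounds measured in a functional assay on MDA-MB-468 cells (Homo sapiens) for cytotoxicity, read by resazurin assay, with a stated time of 72 h; a higher number here means a weaker inhibitor, a lower number a stronger inhibitor:
compound 1 `CCCCOC(=O)CCSC(=S)NCc1cccnc1`, for which compound 1 gives 12800 nM;
compound 2 `NC(=O)CCSC(=S)NCc1cccnc1`, for which compound 2 gives 4630 nM;
compound 3 `Fc1ccccc1-c1nnc(CCSC(=S)NCc2cccnc2)o1`, for which compound 3 gives 3420 nM.

Compound 3 stands at the lowest of the three numbers in this assay. Its gap to compound 2 lies within the scatter, so the two cannot be told apart; its gap to compound 1 lies beyond the scatter.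

Compound 4 `S=C(NCc1cccnc1)SCCc1nnc(-c2cnccn2)o1` has not yet been measured. It differs from compound 3 in one place: pyrazin-2-yl in place of 2-fluorophenyl on an aromatic carbon.

Among the measured compounds shown here, only one measured step exists, a 2.8-fold lower number from compound 1 to compound 2 (0.44 log units; beyond the scatter), and it concerns the carbonyl end of the chain in compounds 1 and 2, not the aromatic ring at the far end of compound 3. For the measured compounds named here, no measured pair speaks to an exchange of one six-membered aromatic ring for another at this position, so there is no step in this assay from which to read a direction. The expectation for compound 4 is therefore a step of a 1.1-fold higher number from compound 3 to compound 4 (0.05 log units; within the scatter), that is, none beyond the scatter. Compound 4 is estimated to give 3800 nM in this assay, with a range from 1500 nM to 10000 nM.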

Compound 4, half-maximal inhibitory concentration: 1710 nM
The estimate for compound 4 lay 2.2-fold (0.35 log units) above the measured number, within the range that was stated.
By their numbers in this assay, from the lowest: compounds 4, 3 and 2 (each within the scatter of the next, the first and the last beyond it); then compound 1.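

In this assay the exchange of 2-fluorophenyl for pyrazin-2-yl on this aromatic carbon of the five-membered aromatic ring with 2 nitrogen and 1 oxygen gives a 2.0-fold lower number from compound 3 to compound 4 (0.30 log units; within the scatter) and so leaves the two compounds indistinguishable. Among the compounds shown here, this is the first reading at this position, and it shows that a six-membered aromatic ring of carbon only, bearing fluorine, and one with 2 hetero atoms and 2 hydrogen-bond acceptors can stand here with no difference beyond the scatter. Nothing in the available data gives a reason for this outcome.

The change removes the fluorine and brings in both ring nitrogens in a single step, so the compounds shown cannot separate the contribution of each, and a plain phenyl, a pyridin-2-yl or a pyrimidinyl group at this carbon would be needed to do so. They also leave open whether this carbon accepts something other than a six-membered aromatic ring, such as a morpholine, a primary amine, a carboxylic acid or a short alkyl chain.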